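The source may report more compounds than this note shows. Statements on the series, on what has been measured and on what is new or still open speak of the compounds shown alone.

Measured so far:
compound 1, `COc1ncc(-c2ccc3ncnc(NCCN(C)C)c3c2)cc1NS(C)(=O)=O` — 12600 nM
compound 2, `COc1ncc(-c2ccc3ncnc(NCCN(C)C)c3c2)cc1NS(=O)(=O)c1ccc(F)cc1` — 9500 nM

Both numbers come from a functional assay on SK-HEP1 cells (Homo sapiens) for antiproliferative activity, read by sulforhodamine B assay, with a stated time of 72 h; on this read-out higher numbers stand for weaker inhibition and lower numbers for stronger inhibition. Within the data shown here, compound 2 carries the smaller of the two values, yet the single measured step, a 1.3-fold lower number from compound 1 to compound 2 (0.12 log units; within the scatter), lies within the scatter, so compound 1 and compound 2 cannot be told apart on these data.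

Compound 3, `COc1ncc(-c2ccc3ncnc(NCCN(C)C)c3c2)cc1NS(=O)(=O)c1ccc(F)cc1F`, differs from compound 2 by fluoro in place of hydrogen on an aromatic carbon. Among the measured compounds shown here, no measured step touches a fluoro entering the aryl ring on the sulfonyl sulfur; the only comparison in hand, a 1.3-fold lower number from compound 1 to compound 2 (0.12 log units; within the scatter), exchanged the whole group on that sulfur and still stayed within the scatter. A step no larger than that is therefore expected, a 1.2-fold lower number from compound 2 to compound 3 (0.07 log units; within the scatter), with no clear direction. For the measured compounds named here, compound 3 is accordingly estimated at 8000 nM, with a range from 3000 nM to 22000 nM; the width reflects that this change has no direct precedent.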

Compound 3, half-maximal inhibitory concentration: 4720 nM
Estimate against measurement, compound 3: 1.7-fold (0.23 log units) above; measured number inside the range.
By their numbers in this assay, from the lowest: compounds 3, 2 and 1 (each within the scatter of the next, the first and the last beyond it).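

In this assay the step of a 2.0-fold lower number from compound 2 to compound 3 (0.30 log units; within the scatter) stays within the scatter, so fluoro added ortho to a large group on the 4-fluorophenyl ring does not by itself separate compound 3 from compound 2. The step of a 2.7-fold lower number from compound 1 to compound 3 (0.43 log units; beyond the scatter) is nonetheless the first in the series beyond the scatter, though modest: measured against methyl on the sulfonyl sulfur, 2,4-difluorophenyl gives a separation that 4-fluorophenyl in compound 2 did not. Nothing available explains this result.

Open, as far as these compounds go, is whether a chloro or methoxy group at the same place on the aryl ring would extend this modest separation or leave it within the scatter. Also open, from the compounds shown here alone, is how a longer amine chain in place of the shared dimethylaminoethyl side chain would read out in this assay on this sulfonamide series.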